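The compounds below may be only part of what the source reports. "The series", "measured", "known", "first", "only" and "open" are said of these compounds alone.

Compound 1 `Cc1c(C(=O)N/N=C\c2cc(O)ccc2O)oc2cccc(O)c12` gives 95500 nM in a functional assay on PC-3 cells (Homo sapiens) for inhibition; a lower number here means a stronger inhibitor, a higher number a weaker inhibitor. Compound 2 `Cc1ccc(O)c(/C=N\NC(=O)c2oc3cccc(O)c3c2C)c1` gives 7350 nM in this assay.

Going by the values given here, compound 2 holds the lowest of the two numbers, with compound 1 the only neighbour, reached by a 13-fold lower number from compound 1 to compound 2 (1.11 log units; beyond the scatter). Compound 3 `Cc1c(C(=O)N/N=C\c2ccc(F)cc2)oc2cccc(O)c12` differs from compound 2 by 4-fluorophenyl in place of 2-hydroxy-5-methylphenyl on a carbon with a double bond to nitrogen. Among the compounds with values here, the single measured step bears on it only loosely: it shows that swapping one group on this ring moved the number a long way, but here both the hydroxy and the methyl leave at once, so the direction is uncertain. A moderate step is expected, a 2.7-fold higher number from compound 2 to compound 3 (0.43 log units; beyond the scatter), most likely toward a higher number. Compound 3 is estimated at 20000 nM, within 5000 nM to 80000 nM.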

Compound 3, half-maximal inhibitory concentration: >= 40000 nM
Compound 3: only a limit was reported; the forecaster's own chance of this, stated with the estimate: 10%; middle value at least 2.0-fold (0.30 log units) away from the limit.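

Putting 4-fluorophenyl on the carbon with a double bond to nitrogen gives an at least 5.4-fold higher number from compound 2 to compound 3 (0.73 log units; beyond the scatter), so this position also tolerates losing the 2-hydroxy-5-methylphenyl group poorly, a change that removes both its hydroxy and its methyl at once. The step between compound 1 and compound 3 cannot be read. Compound 3 has only a limit in this assay: the limit of >= 40000 nM in this assay, at which 1 of the 3 values shown sits.

The compounds shown do not separate the part played by the hydroxy from that of the methyl on this ring. From the compounds shown here alone, how an amine or a carboxylic acid in place of the fluorine would read also remains open.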